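The source may report more compounds than this note shows. Statements on the series, on what has been measured and on what is new or still open speak of the compounds shown alone.

Measured in a functional assay on MCF7 cells (Homo sapiens) for cytotoxicity, read by MTT assay, with a stated time of 72 h; a higher number here means a weaker inhibitor, a lower number a stronger inhibitor:
- compound 1 `CC(C)=C1C(=O)N(c2ccc(Cl)cc2)N(c2ccc(Cl)cc2)C1=O`: 39600 nM
- compound 2 `O=C1C(=Cc2ccc(Cl)cc2)C(=O)N(c2ccc(Cl)cc2)N1c1ccc(Cl)cc1`: 28500 nM
- compound 3 `COc1cc(C=C2C(=O)N(c3ccc(Cl)cc3)N(c3ccc(Cl)cc3)C2=O)cc(OC)c1OC`: 16200 nM

Compound 2 holds the middle place of the three numbers, and its gaps to compound 1 and compound 3 both lie within the scatter. Compound 4 `COc1ccc(C=C2C(=O)N(c3ccc(Cl)cc3)N(c3ccc(Cl)cc3)C2=O)cc1` is not yet measured. It has methoxy in place of chloro on an aromatic carbon, para to a large group: methoxy in place of chloro on an aromatic carbon. Going by the values given here, no measured pair shows this change alone. Compound 3, which also carries methoxy groups, gives 16200 nM, within the scatter of compound 2, so no step beyond the scatter is expected in this assay. The estimated step of a 1.3-fold lower number from compound 2 to compound 4 (0.11 log units; within the scatter) stays small. For compound 4 the expected value is 22000 nM, with an estimated range of 11000 nM to 42000 nM.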

Compound 4, half-maximal inhibitory concentration: > 128000 nM
Compound 4: only a limit was reported (the forecaster's own chance of this, stated with the estimate: 5%); middle value at least 5.8-fold (0.76 log units) from the limit.
By their numbers in this assay, from the lowest: compounds 3, 2 and 1 (each within the scatter of the next, the first and the last beyond it). At a limit, above all of these: compound 4.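

In this assay, going by these compounds alone, the change from 4-chlorophenyl to 4-methoxyphenyl gives an at least 4.4-fold higher number from compound 2 to compound 4 (0.65 log units; beyond the scatter), the first single-place step that lies beyond the scatter. This place on the aromatic ring therefore does not tolerate every substituent equally, and methoxy in place of chloro weakens the read-out. Compound 4 stands only at a limit, so the full size of the step stays unknown: the limit of > 128000 nM in this assay, at which 1 of the 4 values shown sits.

As far as these compounds go, whether an amine or a hydroxyl group here would follow chloro or methoxy stays open. Within the data shown here, compound 3 also carries methoxy groups, but no single-place pair shows how its additional methoxy groups act.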